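This account rests on a few compounds, and the source may have more. Where it says the series, first, only, none or still open, it means among the compounds named here.

Measured compounds:
compound 1, `Cc1ccc(-c2nnn(CC(=O)Nc3cc(C)nn3C3CCCCC3)n2)cc1`
compound 2, `Cc1cccc(-c2nnn(CC(=O)Nc3cc(C)nn3C3CCCCC3)n2)c1`

In an assay on HEK293 cells for activation of Kir3.1/Kir3.2 (Homo sapiens), read by thallium flux (a lower number here means that less compound is needed, a higher number that more compound is needed for the effect), compound 1 gives 111 nM and compound 2 gives 129 nM. Within the data shown here, compound 2 carries the higher of the two numbers, but its only neighbour is compound 1, and the step of a 1.2-fold higher number from compound 1 to compound 2 (0.07 log units; within the scatter) lies within the scatter, so the two stand level. Compound 3, `Cc1cc(NC(=O)Cn2nnc(-c3cccc(C(F)(F)F)c3)n2)n(C2CCCCC2)n1`, follows from compound 2 by trifluoromethyl in place of methyl on an aromatic carbon. Among the measured compounds shown here, no measured step bears on this exchange: the one step known exchanges 4-methylphenyl for 3-methylphenyl and leaves the methyl itself in place, so it says nothing about replacing that methyl. With nothing that speaks for a move in either direction, the change is expected to stay near the scatter in this assay. For compound 3 a value of 150 nM is estimated, with a range of 60 nM to 400 nM. This expectation corresponds to a step of a 1.2-fold higher number from compound 2 to compound 3 (0.07 log units; within the scatter).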

Compound 3, half-maximal effective concentration: 183 nM
Estimate against measurement, compound 3: 1.2-fold (0.09 log units) below; the range from low to high includes it.
By their numbers in this assay, from the lowest: compounds 1, 2 and 3 (each within the scatter of the next).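

In this assay, trifluoromethyl on this aromatic carbon, with four heavy atoms where methyl has one, gives a 1.4-fold higher number from compound 2 to compound 3 (0.15 log units; within the scatter) and so stays level with the methyl compound. Set against the 4-methylphenyl of compound 1, the 3-(trifluoromethyl)phenyl gives a 1.6-fold higher number from compound 1 to compound 3 (0.22 log units; within the scatter) and so also stays within the scatter, which leaves all three compounds level and shows that this position tolerates the larger group without a measurable change in this read-out. No available evidence bears on this result.

The compounds shown leave open whether a group of another kind at this position, such as a methoxy, a nitrile or an amine, would carry the number beyond the scatter. They also leave open how a 4-(trifluoromethyl)phenyl would compare with the 4-methylphenyl of compound 1.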